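A few compounds are considered here, and "the series" means these few. Any claim that something is new, unique, unknown or untested is made for them only; others in the source may bear on it.

For the measured compounds named here, compound 3 `Cc1c(OCCCCOc2ccccc2C(=O)O)ccc(C(=O)CC(C)C)c1C` gives 76.2% in an assay on HEK293 cells for positive allosteric modulation of metabotropic glutamate receptor 2 (Rattus norvegicus), read by thallium flux, with a stated time of 2.5 min (on this read-out lower numbers stand for smaller maximal responses and higher numbers for larger maximal responses), the lowest number of the three measured so far; compound 2 `Cc1ccc(C(=O)O)cc1OCCCCOc1ccc(C(=O)CC(C)C)c(O)c1C` gives 76.9%, within the scatter of compound 3, while compound 1 `Cc1c(OCCCCOc2ccc(C(=O)O)cc2)ccc(C(=O)CC(C)C)c1O` gives 88%, beyond the scatter above compound 3. Compound 4 `Cc1c(OCCCCOc2ccccc2C(=O)O)ccc(C(=O)CC(C)C)c1O` differs from compound 3 by hydroxy in place of methyl on an aromatic carbon. Going by the values given here, the only measured step, a number 11.1 percentage points lower from compound 1 to compound 2 (beyond the scatter), concerns the carboxyphenyl end and does not bear on the change from methyl to hydroxy; compounds 1 and 3 differ in both this group and the carboxyphenyl, so their values show only a combined difference. Among the compounds with values here, with no step to rest on, no change beyond the scatter is expected in this assay. Compound 4 is estimated at 80%, range 68% to 92%, an expected step of a number 3.8 percentage points higher from compound 3 to compound 4 (within the scatter).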

Compound 4, largest response reached (reported as percent of maximum), in percent of the reference or control that the assay uses: 92.4%
Compound 4: middle estimate off by 12.4 percentage points, on the low side; measured number outside the range, above it.
By their numbers in this assay, from the lowest: compounds 3 and 2 (each within the scatter of the next); then compounds 1 and 4 (each within the scatter of the next).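

In this assay hydroxy in place of methyl, ortho to an isobutylcarbonyl group, gives a number 16.2 percentage points higher from compound 3 to compound 4 (beyond the scatter) with the 2-carboxyphenyl end held constant, so the number at this position responds to this change. With hydroxy kept, 2-carboxyphenyl in place of 5-carboxy-2-methylphenyl gives a number 15.5 percentage points higher from compound 2 to compound 4 (beyond the scatter) while 2-carboxyphenyl in place of 4-carboxyphenyl gives a number 4.4 percentage points higher from compound 1 to compound 4 (within the scatter) and these two ends are not told apart here. No evidence bears on the reason for these steps. Still open, as far as these compounds go, is whether methoxy or an amine on the same carbon would match hydroxy, and whether the step from methyl to hydroxy holds with the 4-carboxyphenyl end.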